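The source may hold more compounds than are shown below. What is called first, only, known or untested is meant among the compounds shown, and "the series" means these compounds.

Compound 1 `CC1(C)[C@@H]2CC[C@@]1(C)/C(=N/NC(=O)c1ccccc1)C2`: 1430000 nM
Compound 2 `CC12C=CC3(O1)C(C(=O)N1CCSC13)C2C(=O)N/N=C1\C[C@H]2CC[C@]1(C)C2(C)C`: > 250000 nM
Compound 3 `CC12C=CC3(O1)C(C(=O)N1CCCOC13)C2C(=O)N/N=C1\C[C@H]2CC[C@]1(C)C2(C)C`: > 250000 nM

Of the compounds shown here, three have so far been tested in an ADME assay on Vero cells (Chlorocebus sabaeus) for cytotoxicity, read by spectrophotometry, with a stated time of 4 days; on this read-out higher numbers stand for lower toxicity in this test and lower numbers for higher toxicity in this test. Compound 1 is the only one of them with an actual number, giving 1430000 nM. Compound 2 reached only a limit of the assay, reported as > 250000 nM. Compound 3 likewise stopped at a limit, reported as > 250000 nM. Both of these sit at the limit of > 250000 nM in this assay, at which 2 of the 3 values shown sit, so they tell where compound 2 and compound 3 do not reach rather than where they stand, and compound 1 cannot be ranked against them from these figures.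

The untested compound 4 `CC1(C)[C@@H]2CC[C@@]1(C)/C(=N/NC(=O)c1cccs1)C2` differs from compound 1 in a single place: thiophen-2-yl in place of phenyl on a carbonyl carbon. For the measured compounds named here, no measured pair shares this change, so there is nothing here to anchor its size or direction. Exchanging one aromatic ring for another of similar size at the same spot is, on the evidence available, not expected to move the read-out beyond the usual scatter of this assay. The step of a 1.2-fold lower number from compound 1 to compound 4 (0.08 log units; within the scatter) is therefore estimated to be small. Compound 4 is expected to give about 1200000 nM in this assay, with a likely range from 500000 nM to 3000000 nM.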

Compound 4, half-maximal cytotoxic concentration: 363000 nM
For compound 4 the middle estimate is 3.3-fold (0.52 log units) above the measured one; the whole stated range lies above it.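

Thiophen-2-yl in place of phenyl on a carbonyl carbon gives a 3.9-fold lower number from compound 1 to compound 4 (0.60 log units; beyond the scatter) in this assay, and on this read-out a lower number stands for higher toxicity in this test. For the compounds shown here, this is the first measured pair in the set that differs in one place, and it shows that the choice of aromatic ring on this carbonyl carbon, whose other neighbour is an amide-type nitrogen, can change the result by more than the usual scatter, even though the rest of the molecule stays the same. This single pair gives the size and direction of one exchange and sets no general rule, and nothing shown here bears on why the number fell.

The compounds shown leave open how a furan-2-yl ring, a phenyl ring carrying an amine, or a plain propyl chain would read out on the same carbonyl carbon. Also open, going by these compounds, is whether the same exchange would lower the number in the larger structures of compound 2 and compound 3, whose results are limits of the assay and not numbers.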